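The compounds below may be only part of what the source reports. "The series", "measured", "known", "first", "only" and "open" are said of these compounds alone.

Of the compounds shown here, three built on one shared core have been measured in an assay on RBL-1 cells for inhibition of Polyunsaturated fatty acid 5-lipoxygenase (Rattus norvegicus); on this read-out higher numbers stand for weaker inhibition and lower numbers for stronger inhibition. Compound 1 `COc1ccc(OC)c(C(=O)/C=C/c2ccc(O)c(O)c2)c1` gives 7.8 nM. Compound 2 `CCOc1ccc(O)c(C(=O)/C=C/c2ccc(O)c(O)c2)c1` gives 5.3 nM in this assay. Compound 3 `CCOc1ccc(OC)c(C(=O)/C=C/c2ccc(O)c(O)c2)c1` gives 3.8 nM in this assay, the lowest of the three numbers, although its gap to compound 2 lies within the scatter, so it stands apart only from compound 1. Two steps lead into compound 3: a 2.1-fold lower number from compound 1 to compound 3 (0.31 log units; beyond the scatter), and a 1.4-fold lower number from compound 2 to compound 3 (0.14 log units; within the scatter).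

Compound 4 `CCOc1ccc(OCC)c(C(=O)/C=C/c2ccc(O)c(O)c2)c1` has not yet been measured. It differs from compound 3 by methyl in place of hydrogen on a saturated chain carbon bound to an oxygen on an aromatic ring, so a methoxy becomes an ethoxy. The step from compound 1 to compound 3 bears on this directly, being the same kind of exchange, and it gave a modest lowering beyond the scatter. The step from compound 2 to compound 3 is a different exchange and says less. A step of the same kind but smaller is expected, a 1.4-fold lower number from compound 3 to compound 4 (0.13 log units; within the scatter), possibly staying within the scatter. Compound 4 is therefore estimated at 2.8 nM, with a range from 1.3 nM to 6 nM.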

Compound 4, half-maximal inhibitory concentration: 2.4 nM
Compound 4: middle estimate off by 1.2-fold (0.07 log units), on the high side, within the range that was stated.
By their numbers in this assay, from the lowest: compounds 4, 3, 2 and 1 (each within the scatter of the next, the first and the last beyond it).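

In this assay, the methoxy to ethoxy exchange on compound 3 gives a 1.6-fold lower number from compound 3 to compound 4 (0.20 log units; within the scatter), so this single added methyl does not clearly separate the two compounds, although the same kind of exchange gave a 2.1-fold lower number from compound 1 to compound 3 (0.31 log units; beyond the scatter). Compounds 2, 3 and 4 form a small series at one oxygen, carrying hydrogen, methyl and ethyl, and the full change gives a 2.2-fold lower number from compound 2 to compound 4 (0.34 log units; beyond the scatter), whereas the methyl alone gave a 1.4-fold lower number from compound 2 to compound 3 (0.14 log units; within the scatter). Thus only ethyl in place of the hydrogen gives a difference beyond the usual scatter at this oxygen, and no supporting data shown here explain it.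

The compounds shown leave open whether a longer chain, such as propyl or butyl, on this oxygen would move the number further or reverse the change. They also leave open how a chain ending in an amine or a carboxylic acid would behave there.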